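A Chloro Substituent on the Anilide of Compound 2

The source may hold more compounds than are shown below. What is called first, only, known or untested is meant among the compounds shown, and "the series" means these compounds.

Compound 1 `COc1cc2c(cc1OC)C(CC(=O)O)CC2` carries a free carboxylic acid on its side chain; in a functional assay on the whole organism (strain Wistar) for inhibition, with Rattus norvegicus as the target, read by paw edema, with a stated time of 6 h, at a dose of 100 mg/kg (on this read-out higher numbers stand for more inhibition at the one dose given (going by the name of the read-out) and lower numbers for less inhibition), compound 1 gives 20.4%. Compound 2 `COc1cc2c(cc1OC)C(CC(=O)Nc1ccccc1)CC2` is the corresponding anilide, and in this assay compound 2 gives 38.9%, the higher of the two numbers recorded so far. Within the data shown here, the single measured step, a number 18.5 percentage points higher from compound 1 to compound 2 (beyond the scatter), arose from anilino in place of hydroxy on a carbonyl carbon.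

Compound 3 `COc1cc2c(cc1OC)C(CC(=O)Nc1cccc(Cl)c1)CC2` differs from compound 2 as follows: chloro in place of hydrogen on an aromatic carbon. The chloro group enters on an aromatic carbon of the six-membered carbon-only ring, meta to a large group. No measured step touches this ring; the only step shown concerns the carbonyl carbon, so it does not bear on this change. With nothing to point in either direction, the expected step for compound 3 is a number 1.1 percentage points higher from compound 2 to compound 3 (within the scatter), that is, none beyond the scatter. In this assay compound 3 is therefore estimated at 40%, with a range from 25% to 55%.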

Compound 3, a percentage reported as inhibition, in the whole organism at one dose (the size of the read-out at that dose, not a potency): 38.9%
Compound 3: the middle estimate sits 1.1 percentage points above what was measured, and the stated range covers the measured number.
By their numbers in this assay, from the lowest: compound 1; then compounds 2 and 3 (each within the scatter of the next).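

In this assay, among these compounds, the first reading on the six-membered aromatic ring of the anilide shows that phenyl to 3-chlorophenyl gives no change at the digits printed from compound 2 to compound 3 (within the scatter), so at this place, meta to a large group, chloro in place of hydrogen leaves the read-out within the scatter of compound 2. The gain over the free carboxylic acid also remains with the chloro group present, as (3-chlorophenyl)amino in place of hydroxy gives a number 18.5 percentage points higher from compound 1 to compound 3 (beyond the scatter), a step that matches the one seen earlier with the unsubstituted anilino group. No information is available that would explain the absence of a change beyond the scatter on adding chloro.

On these data alone, whether a methoxy, a trifluoromethyl or a larger group such as phenyl at this same place would also stay within the scatter of compound 2 remains open, as does the outcome for chloro on the other carbons of this ring. Also open, as far as these compounds go, is how far the anilide itself matters, since a benzylamino group or a simple alkylamine on the carbonyl carbon could give a quite different reading at this one dose.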